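A few compounds are considered here, and "the series" means these few. Any claim that something is new, unique, unknown or untested is made for them only; others in the source may bear on it.

In a functional assay on BT-549 cells (Homo sapiens) for inhibition, read by sulforhodamine B assay, with a stated time of 48 h (on this read-out higher numbers stand for weaker inhibition of growth and lower numbers for stronger inhibition of growth), compound 1 `COc1cc(C)cc(-c2nn(CC#N)cc2-c2ccc(-c3cccc(C(C)=O)c3)nc2)c1` gives 15100 nM, compound 2 `Cc1cc(O)cc(-c2nn(CC#N)cc2-c2ccnc(-c3ccc(Oc4ccccc4)cc3)c2)c1` gives 11200 nM, and compound 3 `COc1cc(C)cc(-c2nn(CC#N)cc2-c2ccnc(-c3ccc(N(C)C)cc3)c2)c1` gives 7330 nM. Compound 3 has the lowest of these three numbers; its gap to compound 2 lies within the scatter, while its gap to compound 1 lies beyond it. Compound 4 `Cc1cc(O)cc(-c2nn(CC#N)cc2-c2ccnc(-c3ccc(N(C)C)cc3)c2)c1` differs from compound 3 by hydrogen in place of methyl on an oxygen on an aromatic ring. Going by the values given here, no measured pair shows this change on its own. Compound 2, which also carries the hydroxy group, sits within the scatter of compound 3, so for compound 4 a step of about a 1.0-fold lower number from compound 3 to compound 4 (0.02 log units; within the scatter) is expected, none beyond the scatter. Compound 4 is therefore estimated at 7000 nM, with a range from 3000 nM to 17000 nM.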

Compound 4, concentration for total growth inhibition: 12100 nM
Compound 4: middle estimate off by 1.7-fold (0.24 log units), on the low side, and the stated range covers the measured number.
By their numbers in this assay, from the lowest: compounds 3, 2, 4 and 1 (each within the scatter of the next, the first and the last beyond it).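

Taken alone, methoxy to hydroxy on this aromatic ring gives a step that stays within the scatter in this assay (a 1.7-fold higher number from compound 3 to compound 4 (0.22 log units; within the scatter)), so the earlier compounds' lack of a matched pair for this change is now filled. With the hydroxy group held, dimethylamino in place of phenoxy also stays within the scatter (a 1.1-fold higher number from compound 2 to compound 4 (0.03 log units; within the scatter)). Nothing available explains either step. On these data alone, whether a longer chain such as ethoxy on this oxygen, or an amine or a carboxylic acid in its place, would move the number beyond the scatter remains open.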